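The source may report more compounds than this note shows. Statements on the series, on what has been measured and on what is new or still open speak of the compounds shown alone.

Compound 1 `NS(=O)(=O)c1ccc(S(=O)(=O)CCCO)cc1`: 8.98
Compound 2 `NS(=O)(=O)c1ccc(SCCO)c(F)c1`: 9.76
Compound 3 `NS(=O)(=O)c1ccc(SCCCO)c(F)c1`: 9.64

In a physicochemical assay for acid dissociation, compound 2 gives 9.76. This lies within the scatter of the number for compound 3, while compound 1, at 8.98, stands lower than compound 2 by more than the scatter.

The next compound, compound 4 `NS(=O)(=O)c1ccc(SCCO)c([N+](=O)[O-])c1`, keeps the core of compound 2 and alters one group: nitro in place of fluoro on an aromatic carbon. In words, this is nitro in place of fluoro on an aromatic carbon, ortho to a (2-hydroxyethyl)sulfanyl group and meta to a sulfamoyl group.

Among the measured compounds shown here, only one measured step links two compounds that differ in a single place: a number 0.12 log units lower from compound 2 to compound 3 (within the scatter). That change lies on the chain, not on the aromatic carbon, so it says little here. For the measured compounds named here, no measured pair replaces the fluoro, so the data offer no direct guide. Compound 1, at 8.98, shows that numbers in this small set can differ beyond the scatter, although it differs from compound 2 in more than one place.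

A moderate fall is therefore expected, with real uncertainty, and the estimated step is a number 0.46 log units lower from compound 2 to compound 4 (beyond the scatter). For compound 4 the expected value is 9.3, with an estimated range of 8.9 to 9.7.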

Compound 4, acid dissociation constant: 9.42
Beside the measured number, compound 4's estimate is 0.12 log units below it; the measured number falls inside the stated range.
By their numbers in this assay, from the lowest: compound 1; then compounds 4, 3 and 2 (each within the scatter of the next, the first and the last beyond it).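

Among the compounds shown here, of the two single-place changes in this set, only the one on the aromatic carbon, ortho to a (2-hydroxyethyl)sulfanyl group and meta to a sulfamoyl group, moves the number in this assay beyond the scatter: nitro in place of fluoro gives a number 0.34 log units lower from compound 2 to compound 4 (beyond the scatter), whereas the change on the chain gives a number 0.12 log units lower from compound 2 to compound 3 (within the scatter). The number at this position therefore responds to the group placed there, although the step is modest even though a single fluorine atom gives way to a nitro group of 3 heavy atoms and 2 hydrogen-bond acceptors. No measurement here accounts for the size or the direction of this step.

From the compounds shown here alone, it remains open whether this step is particular to nitro or whether other groups on the same aromatic carbon, such as an amine, a nitrile or a methoxy group, would shift the number as far or further. For the compounds shown here, also open is whether the same swap would give a step of similar size on the longer chain of compound 3, since only one pair of compounds carries this change.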